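The source may hold more compounds than are shown below. What is called first, only, known or untested is meant among the compounds shown, and "the series" means these compounds.

In an ADME assay on Caco-2 cells (Homo sapiens) for cytotoxicity, read by neutral red uptake, with a stated time of 72 h (on this read-out higher numbers stand for lower toxicity in this test and lower numbers for higher toxicity in this test), compound 1 `COc1cc(NC(C)CCCNC(=O)C2CCC3(CC2)OOC2(OO3)C3CC4CC(C3)CC2C4)c2ncccc2c1-c1ccc(Cl)cc1` gives > 50000 nM, which is a limit of the assay and not a number. Compound 2 `COc1cc(NC(C)CCCNC(=O)C2CCC3(CC2)OOC2(OO3)C3CC4CC(C3)CC2C4)c2ncccc2c1-c1ccc(C(F)(F)F)cc1` likewise gives > 50000 nM in this assay, again a limit rather than a number. The change from compound 1 to compound 2 is trifluoromethyl in place of chloro on an aromatic carbon, and the step that the two limits leave unreadable from compound 1 to compound 2 cannot be read because of the limit of > 50000 nM in this assay, at which 2 of the 3 values shown sit. Compound 3 `COc1cc(NC(C)CCCNCC2CCC3(CC2)OOC2(OO3)C3CC4CC(C3)CC2C4)c2ncccc2c1-c1ccc(Cl)cc1` is the only one of the three that yields a number: in this assay compound 3 gives 13200 nM. The difference between the core of compound 3 and the core of compound 1 is not broken down here. Compound 4 `COc1cc(NC(C)CCCNCC2CCC3(CC2)OOC2(OO3)C3CC4CC(C3)CC2C4)c2ncccc2c1-c1ccc(C(F)(F)F)cc1` has not yet been measured; it differs from compound 3 by trifluoromethyl in place of chloro on an aromatic carbon, the same change that separates compound 1 from compound 2, made at the same place. Since the earlier step is unreadable, it supplies no size to carry over, so the expectation for compound 4 rests on compound 3 alone, whose value is 13200 nM. The step from compound 3 to compound 4 is expected to be a 1.1-fold higher number from compound 3 to compound 4 (0.06 log units; within the scatter), within the usual scatter. Compound 4 is therefore estimated at 15000 nM, between 5000 nM and 50000 nM.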

Compound 4, half-maximal cytotoxic concentration: 10300 nM
The estimate for compound 4 lay 1.5-fold (0.16 log units) above the measured number; the range from low to high includes it.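

In this assay, putting trifluoromethyl in place of chloro gives a 1.3-fold lower number from compound 3 to compound 4 (0.11 log units; within the scatter), so on this core the 4-chlorophenyl and the 4-(trifluoromethyl)phenyl compounds cannot be told apart. Among these compounds, the same change on the core of compound 1 gives no size to compare it with, because the values of compound 1 and compound 2 are limits of the assay and not numbers: the limit of > 50000 nM in this assay, at which 2 of the 4 values shown sit. Only one readable step therefore exists, on one core, and it shows neither that the change carries over from one core to the other nor that it does not.

Going by these compounds, it remains open whether other groups at this place, such as a nitrile, a fluoro group or a carboxylic acid, would also stay within the scatter of compound 3 in this assay. Also open, on these data alone, is how a longer chain in the linker would read on the core of compound 3.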